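Swapping the Terminal Amine on a Sulfonamide Side Chain

This account rests on a few compounds, and the source may have more. Where it says the series, first, only, none or still open, it means among the compounds named here.

Measured so far:
Compound 1, `CC(=O)SCC(=O)c1ccc(NS(=O)(=O)c2ccc(OCCCO)cc2)nc1`: "not determined" (no result reported)
Compound 2, `CC(=O)SCC(=O)c1ccc(NS(=O)(=O)c2ccc(OCCCN3CCCC3)cc2)nc1`: 400 nM

Two compounds share a common core and differ only at the end of a chain attached to an oxygen on an aromatic ring. In a functional assay on U226 cells (Homo sapiens) for cytotoxicity (a lower number here means that less compound is needed, a higher number that more compound is needed for the effect), compound 1 gives "not determined" (no result reported), so no number is available for it. In this assay, among the measured compounds shown here, compound 2 gives 400 nM, and this is the only number the series offers, so compound 2 is the sole point of reference.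

Compound 3, `CC(=O)SCC(=O)c1ccc(NS(=O)(=O)c2ccc(OCCCCN(C)C)cc2)nc1`, has not yet been measured. It differs from compound 2 by (dimethylamino)methyl in place of pyrrolidin-1-yl on a saturated chain carbon, three bonds along the chain from an oxygen on an aromatic ring. For the measured compounds named here, with no measured step to guide the size of this change, the step of no change at the digits printed from compound 2 to compound 3 (within the scatter) is expected to stay within the usual scatter, in no clear direction. Compound 3 is therefore estimated at 400 nM, with a range from 150 nM to 1100 nM.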

Compound 3, half-maximal effective concentration: 120 nM
Beside the measured number, compound 3's estimate is 3.3-fold (0.52 log units) above it; measured number below the stated range.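

In this assay the series now has its first measured step, and replacing pyrrolidin-1-yl with (dimethylamino)methyl gives a 3.3-fold lower number from compound 2 to compound 3 (0.52 log units; beyond the scatter) and shows that the number does respond to a change at this place, three bonds along the chain from an oxygen on an aromatic ring. Cut one bond further out, the same difference reads 3-(pyrrolidin-1-yl)propyl to 4-(dimethylamino)butyl, so the ring is lost and the chain is lengthened in one move, and this single step cannot separate the two. Nothing measured here explains the size of this step.

As far as these compounds go, what remains open is which of these two differences goes with the lower number. A 3-(dimethylamino)propyl group or a 4-(pyrrolidin-1-yl)butyl group on the same core would pull them apart, and a morpholine ring would test another cyclic amine.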